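Chlorophenyl exchange in the series: compound 2 to compound 3

The source may hold more compounds than are shown below. What is called first, only, known or untested is meant among the compounds shown, and "the series" means these compounds.

- Compound 1 `NC1=NC2(CCOCC2)N(OCCCOc2ccc(Cl)cc2)C(N)=N1` gives 330 nM
- Compound 2 `NC1=NC2(CCOCC2)N(OCCCOc2ccccc2Cl)C(N)=N1` gives 660 nM
- Compound 3 `NC1=NC2(CCOCC2)N(OCCCOc2ccc(Cl)c(Cl)c2)C(N)=N1` is not yet measured

In a functional assay on HL-60 cells (Homo sapiens) for antiproliferative activity, read by MTT assay, with a stated time of 72 h (on this read-out lower numbers stand for stronger inhibition and higher numbers for weaker inhibition), compound 2 gives 660 nM and stands within the scatter of compound 1 (330 nM). The change to compound 3 puts 3,4-dichlorophenyl in place of 2-chlorophenyl on an oxygen on a saturated carbon. Within the data shown here, the one measured step that bears on this is the exchange of 4-chlorophenyl for 2-chlorophenyl (a 2.0-fold higher number from compound 1 to compound 2 (0.30 log units; within the scatter)), and it stays within the scatter. Among the measured compounds shown here, no measured compound carries the 3,4-dichlorophenyl group, so the data give no direct size for this change. A step beyond the scatter is therefore not expected in this assay, and only a slight lean toward a lower number is anticipated. The expected step is estimated as a 1.9-fold lower number from compound 2 to compound 3 (0.28 log units; within the scatter), and the wide range below reflects how little the two measured compounds can show. The estimated value for compound 3 is 350 nM (expected range 110 nM to 1000 nM).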

Compound 3, half-maximal inhibitory concentration: 1240 nM
Beside the measured number, compound 3's estimate is 3.5-fold (0.55 log units) below it; the whole stated range lies below it.
By their numbers in this assay, from the lowest: compounds 1, 2 and 3 (each within the scatter of the next, the first and the last beyond it).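

In this assay, among these compounds, chloro in place of hydrogen on an aromatic carbon gives a 3.8-fold higher number from compound 1 to compound 3 (0.57 log units; beyond the scatter), the only step in this set of three compounds that lies beyond the scatter and the first sign that the aryl group on this chain can move the read-out measurably; this rests on a single pair and is modest in size. The exchange of 2-chlorophenyl for 3,4-dichlorophenyl on the oxygen on a saturated carbon gives a 1.9-fold higher number from compound 2 to compound 3 (0.27 log units; within the scatter), so that comparison alone does not separate the two groups. Nothing available accounts for the step from the 4-chlorophenyl group to the 3,4-dichlorophenyl group.

The compounds shown leave open how an unsubstituted phenyl, or a methoxy or trifluoromethyl group on the ring, would read in this assay, so chloro cannot yet be set apart from other substituents. As far as these compounds go, whether the step seen with the added chloro would persist with a longer chain on the oxygen, or with a different core, also remains open.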